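This account rests on a few compounds, and the source may have more. Where it says the series, first, only, none or still open, it means among the compounds named here.

Working notes on the series.

Compound 1 `O=[N+]([O-])C1=Cc2cc(C#Cc3ccc(F)cc3)ccc2OC1C(F)(F)F` and compound 3 `O=[N+]([O-])C1=Cc2cc(C#Cc3ccc(Cl)cc3)ccc2OC1C(F)(F)F` share one core and differ only at the end of the extended group. In an assay on 1321N1 cells for antagonist activity at P2Y purinoceptor 6 (Homo sapiens), read by FLIPR and calcium flux (a higher number here means a weaker inhibitor, a lower number a stronger inhibitor), compound 1 gives 8860 nM, and compound 3 gives 5350 nM. The step between them, a 1.7-fold lower number from compound 1 to compound 3 (0.22 log units; within the scatter), is the change (chloro in place of fluoro on an aromatic carbon).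

Compound 2 `O=[N+]([O-])C1=Cc2cc(F)ccc2OC1C(F)(F)F` carries a smaller core; how it differs from compound 1 is not broken down here. In this assay, for the measured compounds named here, compound 2 gives 1150 nM, the lowest of the three numbers so far, and its gaps to compound 3 and to compound 1 both lie beyond the scatter.

Compound 4 `O=[N+]([O-])C1=Cc2cc(Cl)ccc2OC1C(F)(F)F` is not yet measured. It is related to compound 2 by chloro in place of fluoro on an aromatic carbon. Going by the values given here, this is the same kind of change as the one from compound 1 to compound 3, but not the same: there the place was on an aromatic carbon of a six-membered aromatic ring of carbon only, para to a large group, whereas here it is on an aromatic carbon of a six-membered aromatic ring of carbon only, part of a fused or bridged system of two rings, meta to a fused ring and para to a fused ring.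

Among the compounds with values here, only one prior example of this change exists, and it stayed within the scatter. The expectation for compound 4 is a step of about a 1.4-fold lower number from compound 2 to compound 4 (0.16 log units; within the scatter) in this assay, resting on the earlier 1.7-fold lower number from compound 1 to compound 3 (0.22 log units; within the scatter) from compound 1 to compound 3 and on the value of compound 2, 1150 nM. Compound 4 is accordingly estimated at 800 nM, with a range from 350 nM to 2000 nM.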

Compound 4, half-maximal inhibitory concentration: 1790 nM
For compound 4 the middle estimate is 2.2-fold (0.35 log units) below the measured one; the measured number falls inside the stated range.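

In this assay, chloro in place of fluoro on the smaller core gives a 1.6-fold higher number from compound 2 to compound 4 (0.19 log units; within the scatter), so on this core, as on the core of compound 1, the step does not rise above the usual scatter of the measurement. Set side by side, the two steps point in nominally opposite directions, yet the gap between them gives no ground to call the two cores different: the same change on two cores in this assay, a 1.7-fold lower number (0.22 log units; within the scatter) from compound 1 to compound 3 and a 1.6-fold higher number (0.19 log units; within the scatter) from compound 2 to compound 4, 2.6-fold (0.41 log units) apart, within the scatter of two such steps. This shows that, in these two pairs, the exchange of fluoro for chloro can be carried from one core to the other without a step that can be read, but it does not show that the exchange is neutral across the series, since two pairs are a thin base and neither step can be given a reliable direction.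

The compounds shown cover only fluoro and chloro at these places, so how a bromo, a methoxy, an amine or a carboxylic acid would read there remains open. The nitro and trifluoromethyl groups are common to all four compounds, which leaves open what a nitrile in place of nitro, or a methyl in place of trifluoromethyl, would do in this assay.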